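A Hydroxymethyl Group on the Fused Ring of Compound 2

The source may report more compounds than this note shows. Statements on the series, on what has been measured and on what is new or still open speak of the compounds shown alone.

Of the compounds shown here, two built on a shared core have been measured so far. In a functional assay on cells with Free fatty acid receptor 1 (Homo sapiens) as the target, read by FLIPR and calcium flux, with stated times of 20 s and 100 s (on this read-out higher numbers stand for an effect only at larger amounts of compound and lower numbers for an effect already at smaller amounts), compound 1 `O=C1NC(=O)C(Cc2ccc(OCCOC(c3ccccc3)c3ccc(C(F)(F)F)cc3)cc2)S1` gives 11300 nM. Compound 2 `O=C1NC(=O)C(Cc2ccc(OCCn3cnc4ccccc43)cc2)S1` gives 4310 nM in this assay, the lower of the two numbers, and its gap to compound 1 lies beyond the scatter. Compound 3 `O=C1NC(=O)C(Cc2ccc(OCCn3c(CO)nc4ccccc43)cc2)S1` differs from compound 2 by hydroxymethyl in place of hydrogen on an aromatic carbon. Among the measured compounds shown here, no measured pair shows this change, so its direction is unknown; the expected step is small and in either direction, as estimated in a 1.2-fold lower number from compound 2 to compound 3 (0.09 log units; within the scatter). Compound 3 is therefore expected to give 3500 nM in this assay, with a range from 1200 nM to 10000 nM.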

Compound 3, half-maximal effective concentration: "not active" (no number reported)
No number was reported for compound 3; there is nothing to compare the estimate with.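

Among the compounds shown here, compound 3 is reported as "not active" without a number, so no step from compound 2 can be read. Nothing shown gives a cause for this result. As far as these compounds go, the size of the change on adding hydroxymethyl remains open.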